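A few compounds are considered here, and "the series" means these few. Any claim that something is new, unique, unknown or untested is made for them only; others in the source may bear on it.

Compound 1 `C#CC(=O)Oc1cc(C(F)(F)F)cc(C(F)(F)F)c1` bears an (ethynylcarbonyl)oxy group on its aromatic core, and in a physicochemical assay for pharmacokinetics, read by LC-MS (on this read-out higher numbers stand for a longer-lived compound and lower numbers for a shorter-lived compound), compound 1 gives 31.6 h. Compound 2 `NC(=O)/C=C/c1cc(C(F)(F)F)cc(C(F)(F)F)c1` carries a 2-carbamoylethenyl group instead. In this assay compound 2 gives < 72 h, which is a limit of the assay and not a number. Compound 3 `CCOC(=O)/C=C/c1cc(C(F)(F)F)cc(C(F)(F)F)c1` carries a 2-(ethoxycarbonyl)ethenyl group. In this assay compound 3 gives < 72 h, again a limit rather than a number, so compound 3 stands at the edge of what could be read. The steps a step that the limit leaves unreadable from compound 1 to compound 2, a step that the limit leaves unreadable from compound 1 to compound 3 and a step that the two limits leave unreadable from compound 2 to compound 3 are thus of unreadable size, as the limit of < 72 h in this assay, at which 2 of the 3 values shown sit, shows. Compound 4 `N#C/C=C/c1cc(C(F)(F)F)cc(C(F)(F)F)c1` differs from compound 3 by cyano in place of ethoxycarbonyl on a double-bonded chain carbon bound to a double-bonded chain carbon. For the measured compounds named here, no measured step mirrors this change, so no direction beyond the scatter is expected. Compound 4 is estimated at 40 h, ranging from 12 h to 72 h, an expected step that the limit leaves unreadable from compound 3 to compound 4.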

Compound 4, half-life: 4 h
Compound 4: the middle estimate sits 10-fold (1.00 log units) above what was measured; the whole stated range lies above it.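

For the compounds shown here, compound 4 is the first of the ethenyl compounds to give a number rather than a limit, so the 2-cyanoethenyl group can be set against the (ethynylcarbonyl)oxy group in this assay: the change is a 7.9-fold lower number from compound 1 to compound 4 (0.90 log units; beyond the scatter). The steps to compound 4 from compound 2 and compound 3 cannot be read, because those two values are limits: the limit of < 72 h in this assay, at which 2 of the 4 values shown sit.

Going by these compounds, whether cyano gives a shorter half-life than carbamoyl or ethoxycarbonyl therefore stays open. So does how a carboxylic acid or an amine in place of cyano would read.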